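Carbonyl substituent on the shared core: working notes

The source may hold more compounds than are shown below. What is called first, only, known or untested is meant among the compounds shown, and "the series" means these compounds.

Measured so far:
compound 1 `COC(=O)c1cc2cc(NCc3cc(NC(=O)c4ccc(CN5CCC(N(C)C)C5)c(C(F)(F)F)c4)ccc3C)cnc2[nH]1` gives 673 nM in a functional assay on HepG2 cells (Homo sapiens) for antiproliferative activity, read by MTT assay, with a stated time of 72 h; a lower number here means that less compound is needed, a higher number that more compound is needed for the effect
compound 2 `CC(=O)c1cc2cc(NCc3cc(NC(=O)c4ccc(CN5CCC(N(C)C)C5)c(C(F)(F)F)c4)ccc3C)cnc2[nH]1` gives 275 nM in this assay

Going by the values given here, compound 2 holds the lowest of the two numbers; the only neighbour is compound 1, separated by a 2.4-fold lower number from compound 1 to compound 2 (0.39 log units; beyond the scatter), a change of methyl for methoxy on the carbonyl carbon. Compound 3 `CNC(=O)c1cc2cc(NCc3cc(NC(=O)c4ccc(CN5CCC(N(C)C)C5)c(C(F)(F)F)c4)ccc3C)cnc2[nH]1` is not yet measured. It differs from compound 2 at the same carbonyl carbon: methylamino in place of methyl on a carbonyl carbon.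

Among the compounds with values here, only one measured step touches this position, a 2.4-fold lower number from compound 1 to compound 2 (0.39 log units; beyond the scatter), and it compares methoxy with methyl; neither member of that pair carries methylamino, so it gives the size of what this carbonyl substituent can do but not the direction for the new group. Within the data shown here, with no closer precedent, the expectation for compound 3 in this assay is a step of similar size or smaller, more likely towards a higher number than a lower one, expressed as a 1.5-fold higher number from compound 2 to compound 3 (0.16 log units; within the scatter). The estimate for compound 3 is 400 nM, expected to fall between 150 nM and 1200 nM.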

Compound 3, half-maximal effective concentration: 179 nM
The estimate for compound 3 lay 2.2-fold (0.35 log units) above the measured number; the range from low to high includes it.
By their numbers in this assay, from the lowest: compounds 3 and 2 (each within the scatter of the next); then compound 1.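

In this assay, going by these compounds alone, replacing methyl with methylamino on the carbonyl carbon gives a 1.5-fold lower number from compound 2 to compound 3 (0.19 log units; within the scatter), so these two groups cannot be told apart at this position, and the hydrogen-bond donor counted for methylamino brings no separable step in this read-out. Replacing methoxy with methylamino gives a 3.8-fold lower number from compound 1 to compound 3 (0.58 log units; beyond the scatter), which is larger than the earlier methoxy-to-methyl step and, together with it, places compound 1 apart from both compound 2 and compound 3, each separated from it beyond the scatter; among these three compounds, methoxy is the only substituent that stands apart. Nothing available bears on the reason for the separation of compound 1 from the other two.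

Open, as far as these compounds go, is whether this picture extends to other groups on the same carbonyl carbon, such as a dimethylamino group, an ethylamino group or a free carboxylic acid, and whether a longer chain on the amide nitrogen stays level with compound 3. With methyl and methylamino inseparable, the compounds shown also leave open whether any group at this position can move the number clearly below that of compound 2 and compound 3.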